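A Second Methyl Step on a Related Amide Core

A few compounds are considered here, and "the series" means these few. Any claim that something is new, unique, unknown or untested is made for them only; others in the source may bear on it.

Compound 1, `C=CCNC(=O)/C(C)=C(/C)c1ccccc1`: 550 mg/kg
Compound 2, `C=CCNC(=O)/C(C)=C(/C)c1ccc(C)cc1`: 280 mg/kg
Compound 3, `C#CCNC(=O)/C(C)=C(\C)c1ccccc1`: 150 mg/kg

All three numbers come from a toxicity assay on the whole organism (strain Icem-CET (SPF Caw)) for cytotoxicity, with Mus musculus as the target; a lower number here means that less compound is needed, a higher number that more compound is needed for the effect. Compound 1 and compound 2 differ in one place only: methyl in place of hydrogen on an aromatic carbon This change brought a 2.0-fold lower number from compound 1 to compound 2 (0.29 log units; within the scatter). In this assay compound 3 gives 150 mg/kg, a number that lies beyond the usual scatter from that of compound 1 and within it from that of compound 2. How the core of compound 3 differs from the core of compound 1 is not broken down here.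

Compound 4, `C#CCNC(=O)/C(C)=C(\C)c1ccc(C)cc1`, has not yet been measured. It differs from compound 3 in one place: methyl in place of hydrogen on an aromatic carbon The place is described in the same words as for the change from compound 1 to compound 2, so the two changes are the same. In this assay the step is expected to be a 1.5-fold lower number from compound 3 to compound 4 (0.18 log units; within the scatter), because the same change earlier gave a 2.0-fold lower number from compound 1 to compound 2 (0.29 log units; within the scatter), a step that itself lay within the scatter, so the expectation is a modest shift rather than a firm one. Compound 4 is therefore estimated at 100 mg/kg in this assay. The expected range for compound 4 runs from 55 mg/kg to 200 mg/kg, wide enough to take in the chance that the number does not move at all.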

Compound 4, dose for half-maximal effect: 120 mg/kg
Estimate against measurement, compound 4: 1.2-fold (0.08 log units) below; the measured number falls inside the stated range.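

In this assay, placing a methyl in place of hydrogen on an aromatic carbon, para to a large group, gives a 1.3-fold lower number from compound 3 to compound 4 (0.10 log units; within the scatter). Set beside the earlier case, the same change reads alike on the two cores, with no difference between them that rises above the scatter: the same change on two cores in this assay, a 2.0-fold lower number (0.29 log units; within the scatter) from compound 1 to compound 2 and a 1.3-fold lower number (0.10 log units; within the scatter) from compound 3 to compound 4, 1.6-fold (0.20 log units) apart, within the scatter of two such steps Each step also lies within the scatter on its own, so the pair shows only that the change behaves consistently across these two cores; it does not show that the methyl itself moves the number, and two cores say nothing about whether the same would hold on any further core in the series.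

The compounds shown carry only hydrogen or methyl at this place on the ring, so it remains open whether a chlorine atom, a methoxy group or a longer chain such as ethyl there would give a step that clears the scatter. The amide nitrogen also carries only the two short unsaturated chains seen here, and the compounds shown say nothing about how a saturated propyl chain or an added amine on that chain would read in this assay.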